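Cyclopropyl to Isopropyl on the Core: a Cytotoxicity Outlook

The compounds below may be only part of what the source reports. "The series", "measured", "known", "first", "only" and "open" are said of these compounds alone.

Measured compounds:
compound 1, `CS(=O)(=O)CCCn1c(Cn2c(=O)n(C3CC3)c3ccncc32)cc2cc(Cl)ccc21`, > 50000 nM
compound 2, `CS(=O)(=O)CCCn1c(Cn2c(=O)n(C3CC3)c3ccncc32)cc2cc(F)ccc21`, > 50000 nM
compound 3, `N=C(CCCn1c(Cn2c(=O)n(C3CC3)c3ccncc32)cc2cc(Cl)ccc21)NO`, > 50000 nM

All three were tested in an ADME assay on HeLa cells (Homo sapiens) for cytotoxicity, read by ATP content, with a stated time of 3 days; a higher number here means that more compound is tolerated, a lower number that less compound is tolerated. In this assay compound 1 reaches only a limit of the assay, > 50000 nM, and no number. Compound 2 likewise stops at a limit, > 50000 nM. Compound 3 also stops at a limit, > 50000 nM. The two changes measured so far, a step that the two limits leave unreadable from compound 1 to compound 2 and a step that the two limits leave unreadable from compound 1 to compound 3, therefore give no readable size, because of the limit of > 50000 nM in this assay, at which 3 of the 3 values shown sit.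

The next compound is compound 4, `CC(C)n1c(=O)n(Cc2cc3cc(Cl)ccc3n2CCCS(C)(=O)=O)c2cnccc21`. It differs from compound 1 in one place: isopropyl in place of cyclopropyl on an aromatic nitrogen. Among the measured compounds shown here, no measured step touches this position, and the two steps that exist are both hidden by limits, so they offer no direction for the change, only the observation that every compound so far is tolerated up to the top of the tested range.

On that basis compound 4 is expected to give 50000 nM, with a range from 20000 nM to 100000 nM, most probably again only a limit. This estimate corresponds to an expected a number no higher from compound 1 to compound 4 (the limit leaves the size open), that is, no step beyond the scatter.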

Compound 4, half-maximal cytotoxic concentration: > 50000 nM
Compound 4 ended at the assay's limit (the forecaster's own chance of this, stated with the estimate: 85%); the middle value sits exactly at the limit.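

Compound 4 stops at > 50000 nM and this is a limit of the assay, not a number. The change from compound 1 to compound 4 therefore has no readable size, because both compounds stop at the same limit: the limit of > 50000 nM in this assay, at which 4 of the 4 values shown sit.

The compounds shown leave open at what concentration, if any, each of the four becomes toxic to these cells.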